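The compounds below may be only part of what the source reports. "The series", "measured", "known", "first", "only" and "open" are said of these compounds alone.

Measured in a functional assay with Oryctolagus cuniculus as the target; on this read-out higher numbers stand for weaker inhibition and lower numbers for stronger inhibition:

- Compound 1 `CNC(=N)Nc1nc(-c2ccc(OC)cc2)c(-c2ccc(OC)cc2)s1` gives 62 nM
- Compound 2 `COc1ccc(-c2nc(/N=C(\N)NC(C)C)sc2-c2ccc(OC)cc2)cc1` gives > 100 nM as a limit of the assay, not a number
- Compound 3 `COc1ccc(-c2nc(CN(C)C)sc2-c2ccc(OC)cc2)cc1` gives 96 nM

Among the measured compounds shown here, compound 1 and compound 3 are the only two with actual numbers, and a 1.5-fold higher number from compound 1 to compound 3 (0.19 log units; within the scatter) sets no order between them. Compound 2 stands only at its limit, so an at least 1.0-fold lower number from compound 2 to compound 3 (0.01 log units; that floor lies within the scatter) is a floor and says little.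

Compound 4 `CNC(=O)NCc1nc(-c2ccc(OC)cc2)c(-c2ccc(OC)cc2)s1` has not yet been measured. It differs from compound 3 by (methylcarbamoyl)amino in place of dimethylamino on a saturated chain carbon bound to an aromatic carbon, with (methylcarbamoyl)amino in place of dimethylamino on a saturated chain carbon bound to an aromatic carbon. For the measured compounds named here, no measured step makes this exact change. The closest evidence is from swaps of a different group on an aromatic carbon, and a 1.5-fold higher number from compound 1 to compound 3 (0.19 log units; within the scatter) and an at least 1.6-fold higher number from compound 1 to compound 2 (0.20 log units; that floor lies within the scatter) both stay within the scatter. A step beyond the scatter in this assay is therefore not expected, though the estimate remains wide. The expected step is a 1.1-fold lower number from compound 3 to compound 4 (0.03 log units; within the scatter). For compound 4 the estimated value is 90 nM, within an expected range from 30 nM to 270 nM.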

Compound 4, half-maximal inhibitory concentration: 22 nM
Beside the measured number, compound 4's estimate is 4.1-fold (0.61 log units) above it; the measured number lies below the stated range.
By their numbers in this assay, from the lowest: compound 4; then compounds 1 and 3 (each within the scatter of the next). At a limit, above all of these: compound 2.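

In this assay, among the compounds shown here, the earlier compounds showed no step beyond the scatter, whereas (methylcarbamoyl)amino in place of dimethylamino on a saturated chain carbon bound to an aromatic carbon gives a 4.4-fold lower number from compound 3 to compound 4 (0.64 log units; beyond the scatter). Compound 4 also separates from the group carried by compound 1, with a 2.8-fold lower number from compound 1 to compound 4 (0.45 log units; beyond the scatter). The third comparison, an at least 4.5-fold lower number from compound 2 to compound 4 (0.65 log units; beyond the scatter), is only a floor, resting on compound 2's limit of the assay: the limit of > 100 nM in this assay, at which 1 of the 4 values shown sits.

The compounds shown leave open whether the lower number needs the whole (methylcarbamoyl)amino group, since neither an acetylamino group nor an unsubstituted carbamoylamino group stands in that place. They also do not tell whether a longer chain carrying (methylcarbamoyl)amino would keep the number seen for compound 4.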